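The compounds below may be only part of what the source reports. "The series", "measured", "known", "first", "only" and "open" are said of these compounds alone.

Going by the values given here, compound 2, whose structure is `Cc1cc(Nc2cc(-c3ccccc3)[nH]n2)n2nc(SCc3ccccc3Br)nc2n1`, is one of two compounds measured in an ADME assay on GES1 cells (Homo sapiens) for inhibition, read by MTT assay, with a stated time of 72 h; a lower number here means a stronger inhibitor, a higher number a weaker inhibitor. In this assay compound 2 gives 41100 nM, and compound 1, with the structure `Cc1cc(Nc2cc(-c3ccccc3)[nH]n2)n2nc(SCCc3ccccc3)nc2n1`, gives 37400 nM; the two numbers sit within the scatter of each other, so neither can be called the stronger inhibitor. Compound 3, with the structure `Cc1cc(Nc2cc(-c3ccccc3)[nH]n2)n2nc(SCc3cccc4ccccc34)nc2n1`, differs from compound 2 in one place: naphthalen-1-yl in place of 2-bromophenyl on a saturated chain carbon bound to a sulfur. Among the compounds with values here, the only measured step that bears on this change is the one at the same position, a 1.1-fold higher number from compound 1 to compound 2 (0.04 log units; within the scatter), where swapping one group on the saturated chain carbon bound to a sulfur left the number unmoved beyond the scatter. From that single comparison, the step of a 1.0-fold lower number from compound 2 to compound 3 (0.01 log units; within the scatter) is expected to stay within the scatter as well. Compound 3 is therefore estimated to give 40000 nM in this assay, with a likely range from 15000 nM to 110000 nM.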

Compound 3, half-maximal inhibitory concentration: 36300 nM
Estimate against measurement, compound 3: 1.1-fold (0.04 log units) above, and the stated range covers the measured number.
By their numbers in this assay, from the lowest: compounds 3, 1 and 2 (each within the scatter of the next).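

In this assay the change to naphthalen-1-yl brings a second aromatic ring and 10 heavy atoms where 2-bromophenyl had 7, and it removes the bromine, yet the number stays within the scatter: the record shows a 1.1-fold lower number from compound 2 to compound 3 (0.05 log units; within the scatter), and against the benzyl group a 1.0-fold lower number from compound 1 to compound 3 (0.01 log units; within the scatter). On a saturated chain carbon bound to a sulfur, a fused two-ring aromatic group therefore reads the same as the two single-ring groups, which extends the earlier comparison to a larger group. Nothing measured here gives a reason for this lack of movement.

From the compounds shown here alone, whether it would hold for a group of another kind at this place, such as an amine, a carboxylic acid or a longer chain ending in a hydroxyl, stays open. Going by these compounds, how these three compounds compare on any other cells also remains open.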